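Moving a hydroxy group around a hydrazone aryl ring

The source may hold more compounds than are shown below. What is called first, only, known or untested is meant among the compounds shown, and "the series" means these compounds.

Compound 1 `O=C(Cc1csc2nc(-c3ccc(Br)cc3)cn12)N/N=C/c1ccccc1`: 31600 nM
Compound 2 `O=C(Cc1csc2nc(-c3ccc(Br)cc3)cn12)N/N=C/c1ccccc1O`: 11500 nM

Both compounds were tested in a functional assay on UACC-257 cells (Homo sapiens) for inhibition, read by sulforhodamine B assay, with a stated time of 48 h; on this read-out lower numbers stand for stronger inhibition of growth and higher numbers for weaker inhibition of growth. Compound 2 gives the lowest of the two numbers; its nearest neighbour, compound 1, sits at a 2.7-fold lower number from compound 1 to compound 2 (0.44 log units; beyond the scatter). That single step shows that placing a hydroxy group on the aryl ring of the hydrazone makes a modest difference in favour of compound 2.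

Compound 3 `O=C(Cc1csc2nc(-c3ccc(Br)cc3)cn12)N/N=C/c1ccc(O)cc1` has not yet been measured. It differs from compound 2 only in 4-hydroxyphenyl in place of 2-hydroxyphenyl on a carbon with a double bond to nitrogen. Going by the values given here, the one measured step concerns adding a hydroxy group, not moving it, so it bears only loosely on this change: the hydroxy is kept, and the step from compound 1 to compound 2 suggests its presence matters more than its exact spot is known to. Among the compounds with values here, no step in this set shows how large an effect a change of position gives.

For compound 3 the expectation is therefore a number close to that of compound 2, with a step of about a 1.2-fold higher number from compound 2 to compound 3 (0.09 log units; within the scatter) that may well fall within the scatter. Compound 3 is estimated at 14000 nM in this assay, with a range of 5000 nM to 40000 nM.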

Compound 3, concentration for total growth inhibition: 7760 nM
Compound 3: the middle estimate sits 1.8-fold (0.26 log units) above what was measured; the measured number falls inside the stated range.
By their numbers in this assay, from the lowest: compounds 3 and 2 (each within the scatter of the next); then compound 1.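

Moving the hydroxy group, with 4-hydroxyphenyl in place of 2-hydroxyphenyl on a carbon with a double bond to nitrogen, gives a step that does not separate the two compounds in this assay (a 1.5-fold lower number from compound 2 to compound 3 (0.17 log units; within the scatter)). The benefit of adding a hydroxy group is therefore not tied to a single placement on this ring, since the second placement also gives a step beyond the scatter (a 4.1-fold lower number from compound 1 to compound 3 (0.61 log units; beyond the scatter)). Nothing measured here offers a reason for these numbers.

The compounds shown leave open whether a hydroxy group is specifically required, or whether a methoxy group, an amine or a carboxylic acid on the same ring would give a similar number. They also leave open whether a ring carrying two hydroxy groups would go further than either compound with one.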